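Acetamido for triazolyl on the shared oxadiazole-ether series

A few compounds are considered here, and "the series" means these few. Any claim that something is new, unique, unknown or untested is made for them only; others in the source may bear on it.

Measured compounds:
compound 1, `CCCCCCSc1nnc(COc2ccc(NC(C)=O)cc2)o1`, 20.9 mg/kg
compound 2, `CCCCCSc1nnc(COc2ccc(-n3cnnc3)cc2)o1`, 18.7 mg/kg

In a functional assay on the whole organism (strain Kunming) with Mus musculus as the target, with a stated time of 30 min (a lower number here means that less compound is needed, a higher number that more compound is needed for the effect), compound 1 gives 20.9 mg/kg. In this assay compound 2 gives 18.7 mg/kg, the lowest of the two numbers, but its nearest neighbour is compound 1 and the gap between the two is within the scatter, so neither can be called the more potent.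

Compound 3, `CCCCCSc1nnc(COc2ccc(NC(C)=O)cc2)o1`, has not yet been measured in this assay. It arises from compound 2 by the change (acetamido in place of 4H-1,2,4-triazol-4-yl on an aromatic carbon), that is, acetamido in place of 4H-1,2,4-triazol-4-yl on an aromatic carbon. For the measured compounds named here, no step between measured compounds tells what such a change does. Both measured values lie close together, and compound 1 already carries the acetamido group with a value of 20.9 mg/kg, so no step beyond the scatter is expected for compound 3 in either direction. The estimate is that compound 3 gives 20 mg/kg in this assay, with a range from 12 mg/kg to 34 mg/kg. The expected step is a 1.1-fold higher number from compound 2 to compound 3 (0.03 log units; within the scatter).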

Compound 3, dose for half-maximal effect: 22.6 mg/kg
For compound 3 the middle estimate is 1.1-fold (0.05 log units) below the measured one; low and high end bracket the measured number.
By their numbers in this assay, from the lowest: compounds 2, 1 and 3 (each within the scatter of the next).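

In this assay, for the compounds shown here, acetamido in place of 4H-1,2,4-triazol-4-yl, on an aromatic carbon para to a large group, gives the first direct reading of this change: a 1.2-fold higher number from compound 2 to compound 3 (0.08 log units; within the scatter), so the two groups cannot be told apart at this position. The chain receives its first reading as well, since hydrogen in place of methyl on a saturated chain carbon, five bonds along the chain from a sulfur, gives a 1.1-fold higher number from compound 1 to compound 3 (0.03 log units; within the scatter), and this one-carbon difference also cannot be resolved with acetamido in place. No measurement available here offers an explanation for either step.

With both steps inside the scatter, the compounds shown do not establish whether any group at this position, or any change in chain length, shifts the dose in this series. A carboxylic acid or an amine in place of acetamido, or a markedly longer chain on the same core, would show whether the dose can move at all at these two places.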